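A few compounds are considered here, and "the series" means these few. Any claim that something is new, unique, unknown or untested is made for them only; others in the source may bear on it.

Going by the values given here, in an ADME assay on microsomes from liver (Homo sapiens) for metabolic stability (on this read-out lower numbers stand for slow clearance and higher numbers for fast clearance), compound 1 (`CC(C)c1c(NC(=O)Nc2ccnc(C(F)(F)F)c2)cnc2cc(Cl)nn12`) gives 61 mL.min-1.g-1, the only actual number so far. Compound 2 (`O=C(Nc1cnc(-n2nccn2)c(Cl)c1)Nc1cnc2cc(Cl)nn2c1C1CCOCC1`) reports only a limit, < 25 mL.min-1.g-1. Compound 3 (`COCc1c(NC(=O)Nc2cnc(-n3nccn3)c(Cl)c2)cnc2cc(Cl)nn12`) likewise reports only a limit, < 25 mL.min-1.g-1. The remaining evidence is therefore (the limit of < 25 mL.min-1.g-1 in this assay, at which 2 of the 3 values shown sit). Compound 4 (`C[C@H]1COC[C@H](C)N1c1c(NC(=O)Nc2ccnc(C(F)(F)F)c2)cnc2cc(Cl)nn12`) carries 3,5-dimethylmorpholin-4-yl in place of isopropyl on an aromatic carbon of the core of compound 1: 3,5-dimethylmorpholin-4-yl in place of isopropyl on an aromatic carbon. Among the compounds with values here, the one measured step, a step that the two limits leave unreadable from compound 2 to compound 3, offers no size to carry over, so no shift beyond the scatter is expected in this assay. The estimated step is a 1.4-fold lower number from compound 1 to compound 4 (0.13 log units; within the scatter). For compound 4 the expected value is 45 mL.min-1.g-1, with an estimated range from 22 mL.min-1.g-1 to 90 mL.min-1.g-1.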

Compound 4, intrinsic clearance in microsomes: 114 mL.min-1.g-1
Compound 4: middle estimate off by 2.5-fold (0.40 log units), on the low side; the whole stated range lies below it.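

Going by these compounds alone, replacing isopropyl with 3,5-dimethylmorpholin-4-yl gives the first readable step at this position in this assay: a 1.9-fold higher number from compound 1 to compound 4 (0.27 log units; within the scatter). A much larger ring-bearing group on this aromatic carbon therefore leaves the read-out within the scatter of the isopropyl compound. No measured property shown bears on this step.

Open, as far as these compounds go, is how morpholin-4-yl without its methyl groups, or an open-chain amine such as dimethylamino, would read at this position. Also open, from the compounds shown here alone, is how oxan-4-yl or methoxymethyl would read with the rest of compound 1 unchanged.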